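Swapping a Pyridine for a Pyrazole on an Amide Nitrogen

This account rests on a few compounds, and the source may have more. Where it says the series, first, only, none or still open, it means among the compounds named here.

Of the compounds shown here, three have so far been measured in an assay on HEK293 cells for agonist activity at transient receptor potential cation channel subfamily M member 8 (Homo sapiens), read by fluorescence and calcium flux, with a stated time of 15 min; a lower number here means that less compound is needed, a higher number that more compound is needed for the effect. Compound 1 `CCN(Cc1cccs1)C(=O)c1cc2cc(C)ccc2s1` gives 1600 nM, and compound 3 `CCN(Cc1ccccc1)C(=O)COc1ccc(C)cc1` gives 1880 nM. Compound 2 `Cc1ccc(OCC(=O)N(Cc2cccs2)c2ccccn2)cc1` gives 200 nM, the lowest of the three numbers, with the other two compounds lying beyond the usual scatter of it. Compound 4 `Cc1ccc(OCC(=O)N(Cc2cccs2)c2cn[nH]c2)cc1` has not yet been measured in this assay. It differs from compound 2 in a single place: 1H-pyrazol-4-yl in place of pyridin-2-yl on an amide-type nitrogen. Among the compounds with values here, no pair of measured compounds shows this change, so its effect is unknown from these data. The step that this estimate implies is expected to be a 3.0-fold higher number from compound 2 to compound 4 (0.48 log units; beyond the scatter), a moderate rise in the number. Compound 4 is expected to give about 600 nM, within a range from 150 nM to 3000 nM.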

Compound 4, half-maximal effective concentration: 1.4 nM
Compound 4: the middle estimate sits 430-fold (2.63 log units) above what was measured; measured number outside the range, below it.
By their numbers in this assay, from the lowest: compound 4; then compound 2; then compounds 1 and 3 (each within the scatter of the next).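

With 1H-pyrazol-4-yl in place of pyridin-2-yl on the amide-type nitrogen, this assay shows a 140-fold lower number from compound 2 to compound 4 (2.15 log units; beyond the scatter). The earlier compounds shown here offered no pair that tested this position, and this single change shows that the number depends strongly on the ring placed there. Nothing measured here explains the size of the step. On these data alone, it remains open whether the step depends on the hydrogen-bond donor that enters with the pyrazole, which a 1-methyl-1H-pyrazol-4-yl group on the same nitrogen could test. Other five-membered rings, such as imidazole, also remain open.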